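Phenyl to pyridin-3-yl on a shared oxadiazole-free description core

The compounds below may be only part of what the source reports. "The series", "measured", "known", "first", "only" and "open" are said of these compounds alone.

Measured compounds:
compound 1, `COc1ccc(-c2noc(-c3ccccc3)n2)cc1OC1CCCC1`: > 1000000 nM
compound 2, `COc1ccc(-c2noc(-c3ccc(F)cc3)n2)cc1O`: > 1000000 nM
compound 3, `COc1cc(-c2noc(-c3ccncc3)n2)ccc1OCc1ccccc1`: > 1000000 nM

In a functional assay on MCF7 cells (Homo sapiens) for antiproliferative activity, read by MTT assay, with a stated time of 24 h (on this read-out higher numbers stand for weaker inhibition and lower numbers for stronger inhibition), compound 1 gives only a limit of the assay and no number, > 1000000 nM. Compound 2 likewise gives only a limit, > 1000000 nM. Compound 3 too gives only a limit, > 1000000 nM. So compound 1 stands nowhere in particular among the numbers shown: every value is the limit of > 1000000 nM in this assay, at which 3 of the 3 values shown sit, and nothing separates the three compounds from one another.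

The step from compound 1 to compound 4, `COc1ccc(-c2noc(-c3cccnc3)n2)cc1OC1CCCC1`, is a single change: pyridin-3-yl in place of phenyl on an aromatic carbon. For the measured compounds named here, no measured pair differs in one place, so the account has no measured step to lean on; it has only the limits of compound 1, compound 2 and compound 3. From these the writer expects no step beyond the usual scatter in this assay, and in particular expects compound 4 to remain at or near the limit rather than to move into measurable inhibition. The expected step, a step that the limit leaves unreadable from compound 1 to compound 4, is therefore estimated as essentially none. Compound 4 is expected to give about 1500000 nM in this assay, within a range from 200000 nM to 10000000 nM, most likely reported again as a limit.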

Compound 4, half-maximal inhibitory concentration: > 1000000 nM
Compound 4: a limit, no number; the forecaster's own chance of this, stated with the estimate: 85%; the middle value lies beyond the limit too.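

Compound 1 and compound 4 both rest at a limit of the assay and give no number, so no step can be read from the exchange of phenyl for pyridin-3-yl: the limit of > 1000000 nM in this assay, at which 4 of the 4 values shown sit. The compounds shown leave open whether any change on the shared core would bring measurable inhibition in this assay.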